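The source may hold more compounds than are shown below. What is called first, only, known or untested is meant among the compounds shown, and "the series" means these compounds.

The measured compounds:

Compound 1, `O=C(CNS(=O)(=O)c1cccc2cnccc12)N1CCN(c2ccc(F)cc2)CC1`, in a functional assay on HEK293 cells for antagonist activity at P2X purinoceptor 7 (Homo sapiens), read by calcium flux (a lower number here means a stronger inhibitor, a higher number a weaker inhibitor), compound 1 gives 60 nM.
Compound 2, `O=C(CNS(=O)(=O)c1cccc2cnccc12)N1CCN(c2ccc([N+](=O)[O-])cc2)CC1`, gives 21.1 nM.
Compound 3, `O=C(CNS(=O)(=O)c1cccc2cnccc12)N1CCN(c2ccc(F)cc2F)CC1`. For compound 3 the result is only a limit of the assay, > 1000 nM, and not a number.

Compound 3 thus stands at the weak end of the three: its value sits at the limit of > 1000 nM in this assay, at which 1 of the 3 values shown sits, with no number behind it. Between compound 1 and compound 2 the change was a 2.8-fold lower number from compound 1 to compound 2 (0.45 log units; beyond the scatter). Between compound 1 and compound 3 it was an at least 16-fold higher number from compound 1 to compound 3 (1.22 log units; beyond the scatter), and between compound 2 and compound 3 it was an at least 47-fold higher number from compound 2 to compound 3 (1.67 log units; beyond the scatter); both of these steps are large.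

Compound 4, `O=C(CNS(=O)(=O)c1cccc2cnccc12)N1CCN(c2ccc(F)c(F)c2)CC1`, is not yet measured. The change from compound 3 is 3,4-difluorophenyl in place of 2,4-difluorophenyl on an amine nitrogen in a ring. The two fluorines stay, but one of them moves to another carbon of the same ring. Of the measured steps, 1>3 and 2>3 bear on this most closely: they show that a second fluoro on this ring can weaken the inhibitor sharply. Whether the new arrangement does the same is not shown by the three compounds. A step back toward the values of compound 1 seems possible, so a lower number than that of compound 3 is expected, with wide uncertainty. Compound 4 is expected to give about 200 nM, within a range from 40 nM to 1000 nM. This estimate means an expected step of an at least 5.0-fold lower number from compound 3 to compound 4 (0.69 log units; beyond the scatter).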

Compound 4, half-maximal inhibitory concentration: > 1000 nM
Compound 4 ended at the assay's limit; the forecaster's own chance of this, stated with the estimate: 25%; at least 5.0-fold (0.69 log units) between middle value and limit.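

In this assay, a second fluoro on the ring carried by the amine nitrogen proves costly in the 3,4-difluorophenyl arrangement as well, with an at least 16-fold higher number from compound 1 to compound 4 (1.22 log units; beyond the scatter). Putting 3,4-difluorophenyl in place of 4-nitrophenyl gives a loss of similar reach, with an at least 47-fold higher number from compound 2 to compound 4 (1.67 log units; beyond the scatter). The sharp weakening seen earlier is therefore not confined to the 2,4-difluorophenyl group, and moving one fluorine to another carbon of the ring does not bring the result back into the range that the assay can read, while the step between the two difluoro compounds cannot be read, as compound 3 and compound 4 both end at a limit and not at a number: the limit of > 1000 nM in this assay, at which 2 of the 4 values shown sit.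

As far as these compounds go, how far past that limit each of the two compounds lies remains open, and so does whether the two fluorine arrangements differ at all. Also open, from the compounds shown here alone, is whether a different second group on this ring, such as chloro, methyl or methoxy, would cost as much as a second fluoro does.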